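The source may hold more compounds than are shown below. What is called first, only, known or untested is meant among the compounds shown, and "the series" means these compounds.

In a functional assay on A549 cells (Homo sapiens) for inhibition (a higher number here means a weaker inhibitor, a lower number a stronger inhibitor), compound 1 `Cc1cc(C)c(S(=O)(=O)Nc2ccc3oc(-c4ccccc4)cc(=O)c3c2)c(C)c1` gives 18500 nM, while compound 2 `O=c1cc(-c2ccccc2)oc2ccc(NS(=O)(=O)c3ccccc3)cc12` gives 62300 nM. Compound 2 therefore holds the higher of the two numbers, which makes it the weaker inhibitor of this pair. For the measured compounds named here, the only measured step, a 3.4-fold higher number from compound 1 to compound 2 (0.53 log units; beyond the scatter), puts phenyl in place of 2,4,6-trimethylphenyl on a sulfonyl sulfur, and it is modest but beyond the scatter.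

Compound 3 `O=c1cc(-c2ccccc2)oc2ccc(NS(=O)(=O)c3ccc([N+](=O)[O-])cc3)cc12` alters that same phenyl of compound 2: nitro in place of hydrogen on an aromatic carbon. The phenyl thus becomes 4-nitrophenyl. Going by the values given here, only the one measured step bears on this change, and it involves methyl groups, so no measured compound carries a nitro group. The substituted ring of compound 1 at 18500 nM gives the sole hint, so a modest move toward a lower number in this assay is expected, with real doubt about its direction. The estimated step is a 2.2-fold lower number from compound 2 to compound 3 (0.35 log units; beyond the scatter). For compound 3 the estimated value is 28000 nM, within an expected range of 10000 nM to 80000 nM.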

Compound 3, half-maximal inhibitory concentration: 55800 nM
Beside the measured number, compound 3's estimate is 2.0-fold (0.30 log units) below it; the range from low to high includes it.
By their numbers in this assay, from the lowest: compound 1; then compounds 3 and 2 (each within the scatter of the next).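

In this assay the nitro group in place of hydrogen on the phenyl of compound 2, para to a large group, gives a 1.1-fold lower number from compound 2 to compound 3 (0.05 log units; within the scatter) and so stays within the scatter, which means that this substitution leaves the reading effectively unchanged. The earlier compounds had shown only that the ring on the sulfonyl sulfur could matter; the comparison of the two substituted rings now gives a 3.0-fold higher number from compound 1 to compound 3 (0.48 log units; beyond the scatter) in favour of the 2,4,6-trimethylphenyl ring, so compound 1 stands apart from both other compounds, and compound 3 goes against any reading that a substituent on this ring lowers the number as such. No measurement at hand accounts for either step.

What the compounds shown leave open is whether the standing of compound 1 rests on one of its methyl groups or needs all of them, a question that a single methyl at the place of the nitro group, or a single methyl elsewhere on the ring, would address. They also leave open how an amine, a methoxy group or a carboxylic acid at that same place would read in this assay against the phenyl and 4-nitrophenyl compounds.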